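Replacing Methoxyphenyl with Pyridinyl in a Paw Edema Series

The compounds below may be only part of what the source reports. "The series", "measured", "known", "first", "only" and "open" are said of these compounds alone.

Compound 3 `COc1cccc(/C=N/NC(=O)c2cccnc2Nc2cccc(C(F)(F)F)c2)c1` gives 58.8% in a functional assay on the whole organism (strain Wistar) for inhibition, with Rattus norvegicus as the target, read by paw edema, with a stated time of 1 h, at a dose of 10 mg/kg by the intraperitoneal route (on this read-out higher numbers stand for more inhibition at the one dose given (going by the name of the read-out) and lower numbers for less inhibition), the highest of the three numbers, though its lead over compound 1 stays within the scatter. Compound 1 `O=C(N/N=C/c1ccccc1)c1cccnc1Nc1cccc(C(F)(F)F)c1` gives 53.9%, and compound 2 `O=C(N/N=C/c1ccc(F)cc1)c1cccnc1Nc1cccc(C(F)(F)F)c1` gives 43.2%. The step of a number 4.9 percentage points higher from compound 1 to compound 3 (within the scatter) is within the scatter, while the step of a number 15.6 percentage points higher from compound 2 to compound 3 (beyond the scatter) lies beyond it. Compound 4 `O=C(N/N=C/c1cccnc1)c1cccnc1Nc1cccc(C(F)(F)F)c1` has not yet been measured; it differs from compound 3 in one place: pyridin-3-yl in place of 3-methoxyphenyl on a carbon with a double bond to nitrogen. The two measured changes at this carbon, a number 4.9 percentage points higher from compound 1 to compound 3 (within the scatter) and a number 15.6 percentage points higher from compound 2 to compound 3 (beyond the scatter), were modest or within the scatter, and neither brought in a ring nitrogen. A small drop or no step beyond the scatter is therefore expected for compound 4: a number 8.8 percentage points lower from compound 3 to compound 4 (within the scatter). Compound 4 is estimated at 50%, between 38% and 62%.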

Compound 4, a percentage reported as inhibition, in the whole organism at one dose (the size of the read-out at that dose, not a potency): 76.1%
The estimate for compound 4 lay 26.1 percentage points below the measured number; the whole stated range lies below it.
By their numbers in this assay, from the lowest: compound 2; then compounds 1 and 3 (each within the scatter of the next); then compound 4.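

With a ring nitrogen at this carbon, this assay gives a number 17.3 percentage points higher from compound 3 to compound 4 (beyond the scatter), a number 22.2 percentage points higher from compound 1 to compound 4 (beyond the scatter) and a number 32.9 percentage points higher from compound 2 to compound 4 (beyond the scatter). The earlier compounds shown here carried only carbon rings here, so they could not show that pyridin-3-yl would stand above phenyl, 4-fluorophenyl and 3-methoxyphenyl. Nothing available explains why this ring gives the higher number.

The compounds shown leave open whether the place of the ring nitrogen matters, as with pyridin-2-yl or pyridin-4-yl. They also leave open how a pyrimidinyl ring, with a second ring nitrogen, would read.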